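Lengthening the Vinyl Group of Compound 2

A few compounds are considered here, and "the series" means these few. Any claim that something is new, unique, unknown or untested is made for them only; others in the source may bear on it.

Compound 1 (`C=CC(=O)Nc1cccc(Oc2nc(Nc3ccn(C)n3)nc3c2CSCC3)c1`) gives 18600 nM in a functional assay on A549 cells (Homo sapiens) for antiproliferative activity, read by MTT assay, with a stated time of 72 h (on this read-out higher numbers stand for weaker inhibition and lower numbers for stronger inhibition), and compound 2 (`C=CC(=O)Nc1cccc(Oc2nc(Nc3cccc(OC)c3)nc3c2CSCC3)c1`) gives 10100 nM on the same read-out, so the two stand level within the scatter. Their step (a 1.8-fold lower number from compound 1 to compound 2 (0.27 log units; within the scatter)) is the only one measured, and it lies on a nitrogen on an aromatic ring, not at the carbonyl. Compound 3 (`CCC/C=C/C(=O)Nc1cccc(Oc2nc(Nc3cccc(OC)c3)nc3c2CSCC3)c1`) carries pent-1-en-1-yl in place of vinyl on a carbonyl carbon. Going by the values given here, with no measured step at that place, nothing beyond the scatter is expected in this assay, and the expected step is small (a 1.4-fold higher number from compound 2 to compound 3 (0.14 log units; within the scatter)). Compound 3 is estimated at 14000 nM (range 6000 nM to 35000 nM).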

Compound 3, half-maximal inhibitory concentration: 11800 nM
Compound 3: the middle estimate sits 1.2-fold (0.07 log units) above what was measured; the measured number falls inside the stated range.
By their numbers in this assay, from the lowest: compounds 2, 3 and 1 (each within the scatter of the next).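

At the carbonyl carbon, the step with pent-1-en-1-yl in place of vinyl is a 1.2-fold higher number from compound 2 to compound 3 (0.07 log units; within the scatter) in this assay. Going by these compounds alone, this is the first measured change at this place, and it shows that the larger pent-1-en-1-yl group leaves the number level with that of vinyl, within the scatter. Nothing available explains this result.

The compounds shown leave open whether a dimethylamino group or a carboxylic acid on this chain would move the number beyond the scatter. They also leave open whether a saturated pentyl chain would do so.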